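Working notes: changing the aryl amide on compound 3

This account rests on a few compounds, and the source may have more. Where it says the series, first, only, none or still open, it means among the compounds named here.

Measured in a functional assay on BGC-823 cells (Homo sapiens) for inhibition, read by sulforhodamine B assay, with a stated time of 3 days; on this read-out higher numbers stand for weaker inhibition and lower numbers for stronger inhibition:
- compound 1 `O=C1Nc2ccc(F)cc2/C1=C\C(=O)c1ccc(C2CCCCC2)cc1` gives 4450 nM
- compound 2 `O=C1Nc2ccc(F)cc2/C1=C\C(=O)c1cccs1` gives 7750 nM
- compound 3 `CN1CCN(c2cccc(N/C=C3\C(=O)Nc4ccc(NC(=O)c5cccc(F)c5)cc43)c2)CC1` gives 8500 nM

In this assay compound 3 stands at 8500 nM and lies within the scatter of both compound 1 and compound 2, so the numbers do not separate these three. Compound 4 `CN1CCN(c2cccc(N/C=C3\C(=O)Nc4ccc(NC(=O)c5c(Cl)cccc5Cl)cc43)c2)CC1` is the next to be read. It carries 2,6-dichlorophenyl in place of 3-fluorophenyl on a carbonyl carbon, and the rest of compound 3 is unchanged.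

Within the data shown here, no pair of measured compounds differs in one place, so the data offer no direct measure of what such a change does. The expectation therefore starts from compound 3 at 8500 nM and foresees no step beyond the scatter in this assay, in either direction. The estimate amounts to a 1.2-fold lower number from compound 3 to compound 4 (0.08 log units; within the scatter) and remains uncertain on so little data. Compound 4 is estimated at 7000 nM with an expected range of 2000 nM to 25000 nM in this read-out.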

Compound 4, half-maximal inhibitory concentration: 2240 nM
For compound 4 the middle estimate is 3.1-fold (0.49 log units) above the measured one; the range from low to high includes it.
By their numbers in this assay, from the lowest: compounds 4, 1, 2 and 3 (each within the scatter of the next, the first and the last beyond it).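

In this assay, among these compounds, the aryl group on the amide carbonyl is the first place in this set where a single change gives a step beyond the scatter: 2,6-dichlorophenyl in place of 3-fluorophenyl produces a 3.8-fold lower number from compound 3 to compound 4 (0.58 log units; beyond the scatter) and is a modest effect. The earlier compounds shown here could not show this, as no two of them differed in one place and their numbers did not separate. No measurement at hand accounts for the step.

The compounds shown do not tell whether the step follows the chlorine atoms, their number or the loss of fluorine, as plain phenyl, 2-chlorophenyl and 2,6-difluorophenyl are absent from this carbonyl. Also open, from the compounds shown here alone, is whether an amine or a carboxylic acid on this ring would move the number in either direction.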